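Removing one trifluoromethyl from compound 1

The source may hold more compounds than are shown below. What is called first, only, known or untested is meant among the compounds shown, and "the series" means these compounds.

Within the data shown here, in a functional assay on MCF7 cells (Homo sapiens) for antiproliferative activity, with a stated time of 96 h (a higher number here means a weaker inhibitor, a lower number a stronger inhibitor), compound 1 (`Cc1cc(=O)oc2cc(OCC(=O)c3cc(C(F)(F)F)cc(C(F)(F)F)c3)ccc12`) stands lowest of the two numbers so far at 470 nM against compound 2 (`Cc1cc(=O)oc2cc(OCC(=O)c3ccc(C(C)(C)C)cc3)ccc12`) at 20700 nM with the gap beyond the scatter. Compound 3 (`Cc1cc(=O)oc2cc(OCC(=O)c3cccc(C(F)(F)F)c3)ccc12`) comes from compound 1 through one change (hydrogen in place of trifluoromethyl on an aromatic carbon) with hydrogen in place of trifluoromethyl on an aromatic carbon, meta to a trifluoromethyl group. Among the measured compounds shown here, no measured pair differs in one place, so this step has no direct precedent. A rise beyond the scatter is expected in this assay toward weaker inhibition, as an estimated step (a 5.3-fold higher number from compound 1 to compound 3 (0.73 log units; beyond the scatter)). Compound 2 at 20700 nM serves only as a rough upper guide for this expectation. Compound 3 is expected at 2500 nM with an estimated range (700 nM to 9000 nM).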

Compound 3, half-maximal inhibitory concentration: 38400 nM
For compound 3 the middle estimate is 15-fold (1.19 log units) below the measured one; measured number above the stated range.
By their numbers in this assay, from the lowest: compound 1; then compounds 2 and 3 (each within the scatter of the next).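

In this assay, among these compounds, replacing one trifluoromethyl with hydrogen gives an 82-fold higher number from compound 1 to compound 3 (1.91 log units; beyond the scatter) and is the first change that can be read in one place. This place on the aromatic ring therefore matters greatly in this series: the second trifluoromethyl of compound 1 goes with much of its activity, and the trifluoromethyl that remains in compound 3 does not hold that level on its own. Nothing measured on these compounds explains the size of this step.

On these data alone, only trifluoromethyl and hydrogen can be compared at this place, so it remains open whether a smaller substituent such as chlorine or methyl, or a nitrile, a methoxy group or an amine, would recover any of the loss. As far as these compounds go, it also remains open whether the same step would hold on a core other than the core of compound 1.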